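This account rests on a few compounds, and the source may have more. Where it says the series, first, only, none or still open, it means among the compounds named here.

Notes on the series. Three compounds carry numbers in an assay on HEK293 cells for activation of Kir3.1/Kir3.2 (Homo sapiens), read by thallium flux; a lower number here means a smaller maximal response, a higher number a larger maximal response. Compound 3 `Cc1cc(NC(=O)Cn2nnc(-c3cccnc3)n2)n(C2CCCCC2)n1` gives 96% in this assay, the highest of the two plain numbers recorded. The nearest of these belongs to compound 2 `O=C(Cn1nnc(-c2ccccc2)n1)Nc1cc(C2CC2)nn1C1CCCCC1`, which gives 45% in this assay, a gap from compound 3 that lies beyond the usual scatter. Compound 1 `CCC(C)n1nc(C)cc1NC(=O)Cn1nnc(-c2ccccc2)n1` is reported in this assay only as a limit, > 69%, and not as a number. Of the three values, one therefore sits at that limit (the limit of > 69% in this assay, at which 1 of the 3 values shown sits). For the measured compounds named here, no pair of measured compounds differs in one place only, so no measured step is available.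

Compound 4 `Cc1cc(NC(=O)Cn2nnc(-c3cccc(Cl)c3)n2)n(C2CCCCC2)n1` has not been measured. It differs from compound 3 in one place: 3-chlorophenyl in place of pyridin-3-yl on an aromatic carbon. Compound 2 also carries a carbon-only aromatic ring at that place and gives the lower of the two numbers, but it differs from compound 3 elsewhere as well, so this is weak guidance. A modest downward step is expected for this change, of a size near or somewhat beyond the scatter. Compound 4 is expected to reach about 80% in this assay, within 55% to 100%. This estimate means a step of a number 16 percentage points lower from compound 3 to compound 4 (beyond the scatter), expected to be a decrease of moderate size.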

Compound 4, largest response reached (Emax), in percent of the reference or control that the assay uses: 89%
Compound 4: the middle estimate sits 9 percentage points below what was measured; low and high end bracket the measured number.
By their numbers in this assay, from the lowest: compound 2; then compounds 4 and 3 (each within the scatter of the next).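

For the compounds shown here, exchanging pyridin-3-yl for 3-chlorophenyl, on an aromatic carbon of a five-membered aromatic ring with 4 nitrogen, is the first change that can be read on its own: in this assay it gives a number 7 percentage points lower from compound 3 to compound 4 (within the scatter) and so leaves the two compounds indistinguishable. This place therefore accepts a six-membered aromatic ring of carbon only, carrying chlorine, as well as one with a ring nitrogen, and the hydrogen-bond acceptor that leaves with pyridin-3-yl is not required for a large maximal response in this pair. Nothing measured here bears on a cause for this step.

Going by these compounds alone, compound 4 differs from compound 2 in more than one place, so the number of compound 2 at 45% finds no reading in this pair and the place responsible for it stays open. Also open, from the compounds shown here alone, is how this position responds to a group other than an aromatic ring, such as an amine or a carboxylic acid, and whether a methoxy group on the ring would serve in place of chlorine.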